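Piperidine amide series: cytotoxicity notes and compound 3 outlook

A few compounds are considered here, and "the series" means these few. Any claim that something is new, unique, unknown or untested is made for them only; others in the source may bear on it.

Measured so far:
Compound 1, `COc1ccc(Cn2c(C(=O)NC(C)c3ccccc3)cc3sccc32)cc1`, gives in an ADME assay on HEK-293T cells (Homo sapiens) for cytotoxicity, read by luminescence, with a stated time of 24 h (a higher number here means that more compound is tolerated, a lower number that less compound is tolerated), only the limit > 100000 nM.
Compound 2, `COc1ccc(Cn2c(C(=O)N3CCCCC3)cc3sccc32)cc1`, gives in this assay only the limit > 100000 nM.

Compound 2 stands at the limit of this assay, as does every value shown so far, so no reading of its true tolerance exists. For the measured compounds named here, the one step between measured compounds, a step that the two limits leave unreadable from compound 1 to compound 2, cannot be sized because both ends sit at the limit of > 100000 nM in this assay, at which 2 of the 2 values shown sit.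

Compound 3, `COc1ccc(Cn2c(C(=O)N3CCC(C(=O)NC(C)c4ccccc4)CC3)cc3sccc32)cc1`, carries the change ((1-phenylethyl)carbamoyl in place of hydrogen on a saturated ring carbon). Going by the values given here, the only measured step that bears on it is a step that the two limits leave unreadable from compound 1 to compound 2, and that step is unreadable, so nothing in these data points to a shift in either direction beyond the scatter. The expectation is therefore that compound 3 again reaches the limit, and its estimate in this assay is 150000 nM, within 50000 nM to 500000 nM. Going by these compounds, the step that the limit leaves unreadable from compound 2 to compound 3 expected from this estimate lies within the scatter, with the caveat that the true value of compound 2 is unknown.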

Compound 3, half-maximal cytotoxic concentration: > 100000 nM
Compound 3 ended at the assay's limit (the forecaster's own chance of this, stated with the estimate: 80%); the middle value does not contradict the limit.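

No step can be read from compound 2 to compound 3 in this assay, because both end at a limit of the assay and not at a number: the limit of > 100000 nM in this assay, at which 3 of the 3 values shown sit.

Still open, going by these compounds, is the true tolerated concentration of compound 1, compound 2 and compound 3, and whether (1-phenylethyl)carbamoyl in place of hydrogen shifts it in either direction.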